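Swapping the Five-Membered Ring Substituent of Compound 3

A few compounds are considered here, and "the series" means these few. Any claim that something is new, unique, unknown or untested is made for them only; others in the source may bear on it.

Compound 1 `COCc1cc(OC)c(-c2cccc3c(N(CC4CCOCC4)CC4CC4)c(C#N)nn23)c(OC)c1`: 52 nM
Compound 2 `CCCN(CC1CCOCC1)c1c(CC)nn2c(-c3c(OC)cc(COC)cc3OC)cccc12`: 90 nM
Compound 3 `CCc1nn2c(-c3c(OC)cc(COC)cc3OC)cccc2c1N(CC1CCOCC1)CC1CC1`: 50 nM

In an assay on HEK293 cells for displacement of a labelled ligand from corticotropin-releasing factor receptor 1 (Homo sapiens), read by scintillation counting, with a stated time of 2 h (a lower number here means a stronger inhibitor, a higher number a weaker inhibitor), compound 3 gives the lowest of the three numbers, yet both neighbours sit within the scatter: compound 1 lies a 1.0-fold lower number from compound 1 to compound 3 (0.02 log units; within the scatter) away, and compound 2 a 1.8-fold lower number from compound 2 to compound 3 (0.26 log units; within the scatter) away. Compound 4 `COCc1cc(OC)c(-c2cccc3c(N(CC4CCOCC4)CC4CC4)c(OC)nn23)c(OC)c1` differs from compound 3 by methoxy in place of ethyl on an aromatic carbon. Among the measured compounds shown here, the step that bears on this position is the one from compound 1 to compound 3, ethyl in place of cyano, which was a 1.0-fold lower number from compound 1 to compound 3 (0.02 log units; within the scatter) and so showed no effect beyond the scatter. For the measured compounds named here, with only that single step as a guide, compound 4 is expected to stay close to compound 3, with a change of a 1.4-fold higher number from compound 3 to compound 4 (0.15 log units; within the scatter) in this assay. The estimate for compound 4 is 70 nM, within a range of 25 nM to 200 nM.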

Compound 4, half-maximal inhibitory concentration: 51 nM
Estimate against measurement, compound 4: 1.4-fold (0.14 log units) above; low and high end bracket the measured number.
By their numbers in this assay, from the lowest: compounds 3, 4, 1 and 2 (each within the scatter of the next).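

Replacing ethyl with methoxy on this aromatic carbon gives a 1.0-fold higher number from compound 3 to compound 4 (0.01 log units; within the scatter), and replacing cyano with methoxy gives a 1.0-fold lower number from compound 1 to compound 4 (0.01 log units; within the scatter). In this assay, ethyl, cyano and methoxy therefore all lie within the scatter at this position, and the entry of an oxygen and a hydrogen-bond acceptor in place of ethyl produces no step beyond it. As far as these compounds go, whether an amine, a carboxylic acid or a longer chain at this position would shift the number remains open. Nothing available explains why these three groups give such similar numbers.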